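Removing the Methyl from the Weaker Analogue

This account rests on a few compounds, and the source may have more. Where it says the series, first, only, none or still open, it means among the compounds named here.

Of the compounds shown here, two built on a shared core have been measured. Compound 1 `C/C(=N\Nc1nc2ccccc2o1)c1cc2ccccc2cn1` is the stronger of the pair: in a functional assay on CCRF-CEM cells (Homo sapiens) for antiproliferative activity, read by MTT assay (a lower number here means a stronger inhibitor, a higher number a weaker inhibitor), compound 1 gives 140 nM. Compound 2 `C/C(=N\Nc1nc2ccccc2o1)c1nccnc1C` carries a different six-membered aromatic ring with a methyl group, and in this assay compound 2 gives 1300 nM, the higher of the two numbers, lying well above compound 1 and beyond the usual scatter. Compound 3 `C/C(=N\Nc1nc2ccccc2o1)c1cnccn1` has not yet been measured; it differs from compound 2 in one place: hydrogen in place of methyl on an aromatic carbon. Among the measured compounds shown here, no measured pair shows the effect of this change, so nothing anchors its size. The expected step is a 1.3-fold lower number from compound 2 to compound 3 (0.11 log units; within the scatter), a shift that would likely fall within the scatter, though a modest gain cannot be excluded. Compound 3 is estimated at 1000 nM, with a plausible range from 400 nM to 3000 nM.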

Compound 3, half-maximal inhibitory concentration: 430 nM
For compound 3 the middle estimate is 2.3-fold (0.37 log units) above the measured one; measured number inside the range.
By their numbers in this assay, from the lowest: compound 1; then compound 3; then compound 2.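

In this assay, among the compounds shown here, replacing the methyl with hydrogen on the aromatic carbon next to the ring nitrogen gives a 3.0-fold lower number from compound 2 to compound 3 (0.48 log units; beyond the scatter) and so provides the first measured one-place step. The position is therefore not indifferent to what it carries: the loss of a single carbon there moves the number beyond the usual scatter, and of the two substituents compared at this carbon, hydrogen gives the lower number. Nothing at hand bears on why the number moves at this position. Going by these compounds, it remains open whether an ethyl group, a methoxy group, a chlorine or an amine on this same carbon would lower the number further or raise it again. The compounds shown also leave open whether a methyl on the other carbons of this ring would produce a step of similar size.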